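The source may report more compounds than this note shows. Statements on the series, on what has been measured and on what is new or still open speak of the compounds shown alone.

Compound 1 `Nc1nc2cc(Cl)c(Cl)cc2n1Cc1cccc(C(F)(F)F)c1` carries a trifluoromethyl group on its pendant ring, and in a functional assay on CEM-SS cells (Homo sapiens) for cytotoxicity (a lower number here means a stronger inhibitor, a higher number a weaker inhibitor), compound 1 gives 34000 nM. Compound 2 `Nc1nc2cc(Cl)c(Cl)cc2n1Cc1cccc([N+](=O)[O-])c1` differs by nitro in place of trifluoromethyl on an aromatic carbon, and in this assay compound 2 gives 47000 nM; the step is a 1.4-fold higher number from compound 1 to compound 2 (0.14 log units; within the scatter). Compound 3 `FC(F)(F)c1ccc(Cn2c(Br)nc3cc(Cl)c(Cl)cc32)cc1` has a different core; the difference between the two cores is not broken down here. In this assay compound 3 gives only a limit of the assay, > 100000 nM. This is the limit of > 100000 nM in this assay, at which 1 of the 3 values shown sits. Compound 4 `O=[N+]([O-])c1ccc(Cn2c(Br)nc3cc(Cl)c(Cl)cc32)cc1` differs from compound 3 by nitro in place of trifluoromethyl on an aromatic carbon, the same kind of change as before, but here the group sits para to a large group rather than meta. Since the earlier step of a 1.4-fold higher number from compound 1 to compound 2 (0.14 log units; within the scatter) stayed within the scatter, compound 4 is expected to remain at a limit too, estimated at 130000 nM in this assay. That estimate means a step that the limit leaves unreadable from compound 3 to compound 4.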

Compound 4, half-maximal inhibitory concentration: > 100000 nM
Compound 4 was reported as a limit (the forecaster's own chance of this, stated with the estimate: 80%); the middle value does not contradict the limit.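

Compound 3 and compound 4 both stand at a limit in this assay, so no step between them can be read: the limit of > 100000 nM in this assay, at which 2 of the 4 values shown sit.

The compounds shown leave open whether nitro in place of trifluoromethyl changes the number at all on the core of compound 3.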